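The source may hold more compounds than are shown below. What is called first, only, known or untested is meant among the compounds shown, and "the series" means these compounds.

In a physicochemical assay, read by spectrophotometry, with a stated time of 20 min (on this read-out lower numbers stand for stronger inhibition and higher numbers for weaker inhibition), compound 1 `CC(C)(C)Oc1ccc(-c2oc3cc(O)cc(O)c3c(=O)c2O)cc1` gives 452000 nM, while compound 2 `O=C(/C=C/c1ccc(Cl)cc1)c1ccccc1O` gives 6100000 nM, the higher and therefore weaker of these two numbers. Compound 3 `CC(C)(C)c1ccc(/C=C/C(=O)c2ccccc2O)cc1` differs from compound 2 in one place, with tert-butyl in place of chloro on an aromatic carbon. For the measured compounds named here, no measured pair shows what this swap does, so no step beyond the usual scatter is expected, and a small shift toward stronger inhibition is only a slight lean. The expected change is a 1.2-fold lower number from compound 2 to compound 3 (0.09 log units; within the scatter). For compound 3 the estimate is 5000000 nM, with an expected range from 1500000 nM to 15000000 nM.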

Compound 3, half-maximal inhibitory concentration: 17100000 nM
Estimate against measurement, compound 3: 3.4-fold (0.53 log units) below, and the stated range ends below it.
By their numbers in this assay, from the lowest: compound 1; then compound 2; then compound 3.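

Replacing chloro with tert-butyl at this position, para to a large group, gives a 2.8-fold higher number from compound 2 to compound 3 (0.45 log units; beyond the scatter) in this assay as the first measured effect of this swap. The step is modest but shows that inhibition is weaker with tert-butyl here, although neither group adds a ring, a hydrogen-bond donor or acceptor, or a charge. Nothing measured gives a reason for this step. Going by these compounds, whether methyl, fluoro, an amine or a carboxylic acid at this position would give stronger or weaker inhibition remains open. So does whether the same swap would have a similar effect on the core of compound 1.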